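A few compounds are considered here, and "the series" means these few. Any claim that something is new, unique, unknown or untested is made for them only; others in the source may bear on it.

In a functional assay on HEK293 cells (Homo sapiens) for cytotoxicity (on this read-out higher numbers stand for lower toxicity in this test and lower numbers for higher toxicity in this test), compound 1, `CCCCNc1cccc(N2C[C@@H](c3ccc(OC)c(OC4CCCC4)c3)CC2=O)c1`, gives > 10000 nM, which is a limit. Compound 2, `COc1ccc(S(=O)(=O)Nc2cccc(N3C[C@@H](c4ccc(OC)c(OC5CCCC5)c4)CC3=O)c2)cc1`, gives a limit too, > 10000 nM. Compound 3, `COc1ccc([C@H]2CC(=O)N(c3cccc(NS(=O)(=O)c4cc(C)ccc4OC)c3)C2)cc1OC1CCCC1`, also gives a limit, > 10000 nM. Compound 3 therefore has no exact number, and the data so far show (the limit of > 10000 nM in this assay, at which 3 of the 3 values shown sit).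

Compound 4, `COc1ccc([C@H]2CC(=O)N(c3cccc(NS(=O)(=O)c4ccc(F)cc4)c3)C2)cc1OC1CCCC1`, is the next to be read, and it changes compound 3 in one place, on a sulfonyl sulfur: 4-fluorophenyl in place of 2-methoxy-5-methylphenyl on a sulfonyl sulfur. Going by the values given here, the closest precedent is a step that the two limits leave unreadable from compound 2 to compound 3, which also exchanges one aryl group on the sulfonyl sulfur for another. Two further comparisons, a step that the two limits leave unreadable from compound 1 to compound 2 and a step that the two limits leave unreadable from compound 1 to compound 3, replace butyl with an arylsulfonyl group on the same nitrogen. None of these steps has a readable size, so they give no direction for the new exchange. The expected change is a step that the limit leaves unreadable from compound 3 to compound 4, with no shift beyond the scatter anticipated. Compound 4 is estimated at 12000 nM, with an expected range from 6000 nM to 30000 nM, and it will most likely be reported only as a limit.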

Compound 4, half-maximal cytotoxic concentration: > 10000 nM
Compound 4 gave a limit, no number; the forecaster's own chance of this, stated with the estimate: 85%; the middle value does not contradict the limit.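

Compound 4, like compound 1, compound 2 and compound 3, gives only a limit, so none of the steps among these compounds can be read in this assay. The compounds shown leave open whether any of these groups differ in cytotoxicity at all, as every value rests on one limit: the limit of > 10000 nM in this assay, at which 4 of the 4 values shown sit.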